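This account rests on a few compounds, and the source may have more. Where it says the series, first, only, none or still open, it means among the compounds named here.

Measured compounds:

Compound 1, `CC/C=C\C(=O)Nc1cc(Nc2nccc(-c3cn(C)c4ccccc34)n2)c(OC)cc1N(C)CCN(C)C`, gives 1530 nM in a functional assay on A549 cells (Homo sapiens) for antiproliferative activity, read by MTT assay, with a stated time of 72 h; on this read-out higher numbers stand for weaker inhibition and lower numbers for stronger inhibition.
Compound 2, `CCC/C=C\C(=O)Nc1cc(Nc2nccc(-c3cn(C)c4ccccc34)n2)c(OC)cc1N(C)CCN(C)C`, gives 808 nM in this assay.
Compound 3, `CC/C=C\C(=O)Nc1cc(Nc2ncc(C#N)c(-c3cn(C)c4ccccc34)n2)c(OC)cc1N(C)CCN(C)C`, gives 162 nM in this assay.

Compound 3 gives the lowest of the three numbers in this assay. Its nearest neighbour is compound 2, whose number is higher by more than the scatter, and compound 1 stands further off still; the gap from compound 1 to compound 3 is told by a 9.4-fold lower number from compound 1 to compound 3 (0.98 log units; beyond the scatter), a cyano in place of hydrogen on an aromatic carbon.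

Compound 4, `CCC/C=C\C(=O)Nc1cc(Nc2ncc(C#N)c(-c3cn(C)c4ccccc34)n2)c(OC)cc1N(C)CCN(C)C`, has not yet been measured in this assay. It differs from compound 3 in one place: methyl in place of hydrogen on a saturated chain carbon, two bonds along the chain from a double-bonded chain carbon.

The same change has been made once before on this shared core, from compound 1 to compound 2, where it gave a 1.9-fold lower number from compound 1 to compound 2 (0.28 log units; within the scatter), a shift that stays within the scatter. On that precedent the change is expected to be small, pointing toward a lower number but not certainly beyond the scatter. The step that this expectation means is estimated as a 1.5-fold lower number from compound 3 to compound 4 (0.17 log units; within the scatter).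

Compound 4 is therefore expected to give about 110 nM in this assay, with a likely range from 50 nM to 250 nM.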

Compound 4, half-maximal inhibitory concentration: 166 nM
Beside the measured number, compound 4's estimate is 1.5-fold (0.18 log units) below it, within the range that was stated.
By their numbers in this assay, from the lowest: compounds 3 and 4 (each within the scatter of the next); then compounds 2 and 1 (each within the scatter of the next).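

In this assay, the methyl in place of hydrogen on a saturated chain carbon, two bonds along the chain from a double-bonded chain carbon, can now be read on the core that carries the cyano group, where the step is a 1.0-fold higher number from compound 3 to compound 4 (0.01 log units; within the scatter). The but-1-en-1-yl to pent-1-en-1-yl difference thus stays within the scatter on both cores, and its two steps agree: the same change on two cores in this assay, a 1.9-fold lower number (0.28 log units; within the scatter) from compound 1 to compound 2 and a 1.0-fold higher number (0.01 log units; within the scatter) from compound 3 to compound 4, 1.9-fold (0.29 log units) apart, within the scatter of two such steps. Among the compounds shown here, the cyano in place of hydrogen on an aromatic carbon, earlier seen only with the but-1-en-1-yl chain, now also appears with the pent-1-en-1-yl chain as a 4.9-fold lower number from compound 2 to compound 4 (0.69 log units; beyond the scatter), so it goes beyond the scatter with both chains, and the two steps agree: the same change on two cores in this assay, a 9.4-fold lower number (0.98 log units; beyond the scatter) from compound 1 to compound 3 and a 4.9-fold lower number (0.69 log units; beyond the scatter) from compound 2 to compound 4, 1.9-fold (0.29 log units) apart, within the scatter of two such steps.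

Going by these compounds, whether a longer chain, such as hex-1-en-1-yl, or a chain ending in an amine would leave the number equally unchanged remains open. On these data alone, it is also open whether a carboxamide or a chlorine in place of the cyano group on that aromatic carbon would give a step of similar size.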